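Notes on compounds 1 to 3: cytotoxicity on BJ cells

A few compounds are considered here, and "the series" means these few. Any claim that something is new, unique, unknown or untested is made for them only; others in the source may bear on it.

Compound 1 `CCOC(=O)CCCCCOc1cccc(CN(C(=O)c2ccc(-c3cccc4ccccc34)cc2)C(C)C)c1` carries a naphthalen-1-yl group on the shared core. In an ADME assay on BJ cells (Homo sapiens) for cytotoxicity, read by CellTiter-Glo and resazurin assay, with a stated time of 72 h (on this read-out higher numbers stand for an effect only at larger amounts of compound and lower numbers for an effect already at smaller amounts), compound 1 returns only the limit > 26000 nM, not a number. Compound 2 `CCOC(=O)CCCCCOc1cccc(CN(C(=O)c2ccc(-c3cc(OC)cc(OC)c3)cc2)C(C)C)c1` has 3,5-dimethoxyphenyl in place of naphthalen-1-yl on an aromatic carbon. In this assay compound 2 likewise returns only the limit > 26000 nM. The step that the two limits leave unreadable from compound 1 to compound 2 cannot be read: both ends are limits, as the limit of > 26000 nM in this assay, at which 2 of the 2 values shown sit, shows. Among the measured compounds shown here, compound 2 therefore stands at the same limit as every value so far, with no number to rank it against compound 1.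

Compound 3 `CCOC(=O)CCCCCOc1cccc(CN(C(=O)c2ccc(-c3cccc([N+](=O)[O-])c3)cc2)C(C)C)c1` is the next member: 3-nitrophenyl in place of 3,5-dimethoxyphenyl on an aromatic carbon. No measured step bears on this exchange, and the single step shown is unreadable. For the measured compounds named here, with both values so far sitting at the limit, the expectation for compound 3 in this assay is again a reading at the limit or beyond it. The step that the limit leaves unreadable from compound 2 to compound 3 is expected to be too small to read. Compound 3 is estimated at 40000 nM, between 20000 nM and 100000 nM.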

Compound 3, half-maximal effective concentration: < 1.3 nM
Compound 3 gave a limit, no number; the forecaster's own chance of this, stated with the estimate: 85%; at least 30000-fold (4.48 log units) between middle value and limit.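

At this position, on an aromatic carbon para to a large group, the choice of substituent now makes a measurable difference in this assay: 3-nitrophenyl in place of 3,5-dimethoxyphenyl gives an at least 20000-fold lower number from compound 2 to compound 3 (4.30 log units; beyond the scatter), and 3-nitrophenyl in place of naphthalen-1-yl gives an at least 20000-fold lower number from compound 1 to compound 3 (4.30 log units; beyond the scatter). For compound 3 the reading is < 1.3 nM, a limit of the assay and not a number. Among the compounds shown here, the step between compound 1 and compound 2 cannot be read, so these two new steps are the first readable sign of how much this position can matter, and the counts do not separate 3,5-dimethoxyphenyl from 3-nitrophenyl, since both have one six-membered aromatic ring of carbon only, 0 hydrogen-bond donors and 2 hydrogen-bond acceptors.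

Going by these compounds, whether the step belongs to the nitro group as such or to any group of this kind stays open, and an amine, a nitrile or a carboxylic acid in place of the nitro group would bear on that. For the compounds shown here, with only three compounds, no wider pattern can be drawn for the series.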